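Sulfonamide Aryl Exchange and Expected Cell Tolerance

The source may hold more compounds than are shown below. What is called first, only, known or untested is meant among the compounds shown, and "the series" means these compounds.

The series shares a core carrying a bromonaphthyl ether and a chlorophenyl group. In an ADME assay on HepG2 2.2.15 cells (Homo sapiens) for cytotoxicity (a lower number here means that less compound is tolerated, a higher number that more compound is tolerated), compound 1 `Clc1ccc(C(Oc2ccc3cc(Br)ccc3c2)c2cnc(NCC3CCCCC3)s2)cc1` is recorded as "not toxic" (no number reported). Compound 2 `Cc1noc(C)c1C(=O)Nc1ncc(C(Oc2ccc3cc(Br)ccc3c2)c2ccc(Cl)cc2)s1` is likewise recorded as "not toxic" (no number reported). Compound 3 `Cc1ccc(S(=O)(=O)Nc2ncc(C(Oc3ccc4cc(Br)ccc4c3)c3ccc(Cl)cc3)s2)c2ccccc12` reaches only the limit of this assay, > 50000 nM, so no single number describes where it stands; it sits at the limit of > 50000 nM in this assay, at which 1 of the 3 values shown sits. Compound 4 `O=S(=O)(Nc1ncc(C(Oc2ccc3cc(Br)ccc3c2)c2ccc(Cl)cc2)s1)c1cccc2nsnc12` differs from compound 3 by a group of 9 heavy atoms (6 carbon, 2 nitrogen, 1 sulfur; one five-membered aromatic ring with 3 hetero atoms, one six-membered aromatic ring of carbon only) in place of a group of 11 heavy atoms (11 carbon; 2 six-membered aromatic rings of carbon only), on a sulfonyl sulfur. Among the compounds with values here, no measured step links the two, and with every value in this assay either a limit or a plain absence of toxicity, no step beyond the scatter is expected in this assay, as a number no higher from compound 3 to compound 4 (the limit leaves the size open) reflects. Compound 4 is therefore estimated at 50000 nM, within a range from 20000 nM to 120000 nM, most likely again reported only as a limit.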

Compound 4, half-maximal cytotoxic concentration: "not toxic" (no number reported)
Nothing numeric was reported for compound 4, and the estimate cannot be compared.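

No step can be read from compound 3 to compound 4: the former carries only a limit, the latter only a note of no toxicity. The compounds shown leave open at what concentration, if any, cytotoxicity would appear for any of them in this assay.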